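From a Small Methoxy Group to a Phenethyl Chain

The compounds below may be only part of what the source reports. "The series", "measured", "known", "first", "only" and "open" are said of these compounds alone.

Going by the values given here, compound 2 `CCCCNc1nc(N)nc2cccc(OC)c12` gives 0.1 uM in an ADME assay on HEK293 cells for agonist activity at Toll-like receptor 8 (Homo sapiens), read by a luciferase reporter, with a stated time of 6 h (on this read-out lower numbers stand for an effect already at smaller amounts and higher numbers for an effect only at larger amounts of compound), the lowest of the two numbers measured so far. Compound 1 `CCCCNc1nc(N)nc2cccc(C)c12` gives 0.3 uM in this assay, and the step of a 3.0-fold lower number from compound 1 to compound 2 (0.48 log units; beyond the scatter) separates the two. Compound 3 `CCCCNc1nc(N)nc2cccc(CCc3ccccc3)c12` carries the change (phenethyl in place of methoxy on an aromatic carbon). Among the compounds with values here, the only measured step concerns a different kind of exchange at the same carbon, so it offers little guidance on direction, and no step beyond the scatter is firmly expected. Compound 3 is estimated to give about 0.3 uM, within 0.05 uM to 2 uM. The expected step is a 3.0-fold higher number from compound 2 to compound 3 (0.48 log units; beyond the scatter).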

Compound 3, minimum effective concentration: 0.47 uM
The estimate for compound 3 lay 1.6-fold (0.19 log units) below the measured number; the range from low to high includes it.
By their numbers in this assay, from the lowest: compound 2; then compounds 1 and 3 (each within the scatter of the next).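

This carbon of the shared core tolerates a much larger group than methoxy or methyl, though phenethyl gives up the gain seen with methoxy in this assay (a 4.7-fold higher number from compound 2 to compound 3 (0.67 log units; beyond the scatter)). Adding benzyl to the methyl of compound 1 leaves the number within the scatter (a 1.6-fold higher number from compound 1 to compound 3 (0.19 log units; within the scatter)), so the added aromatic ring brings no measurable change from that compound. Nothing available here explains either step.

Still open, going by these compounds, is how an amine, a hydroxyl or a longer alkoxy chain on this carbon would read. The compounds shown also cannot separate the effect of the phenyl ring from that of the two-carbon link in phenethyl.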